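This account rests on a few compounds, and the source may have more. Where it says the series, first, only, none or still open, it means among the compounds named here.

Compound 3 `COc1ccc(S(=O)(=O)N2CCc3cccc(NCc4ccccc4)c32)cc1` gives > 10000 nM in a functional assay on TSGH 9201 cells (Homo sapiens) for cytotoxicity (on this read-out lower numbers stand for stronger inhibition and higher numbers for weaker inhibition), and that value is a limit, not a number. It stands at the limit of > 10000 nM in this assay, at which 1 of the 3 values shown sits. Compound 4 `COc1ccc(S(=O)(=O)N2CCc3cccc(NC(=O)c4ccccc4)c32)cc1` differs from it by benzoyl in place of benzyl on a nitrogen on an aromatic ring, with benzoyl in place of benzyl on a nitrogen on an aromatic ring. The closest measured step is an at least 920-fold higher number from compound 2 to compound 3 (2.96 log units; beyond the scatter), where compound 2 `COc1ccc(S(=O)(=O)N2CCc3cccc(NC(=O)c4ccncc4)c32)cc1`, at 10.8 nM, loses its carbonyl. The step of an 11-fold lower number from compound 1 to compound 2 (1.03 log units; beyond the scatter) shows that the group on the carbonyl also counts, with compound 1 `COc1ccc(S(=O)(=O)N2CCc3cccc(NC(=O)c4ccc([N+](=O)[O-])cc4)c32)cc1` at 116 nM. Compound 4 regains the carbonyl, so a large drop in the number is expected, read backwards from those two amides. The expected change is an at least 160-fold lower number from compound 3 to compound 4 (2.22 log units; beyond the scatter). The estimate for compound 4 is 60 nM, within an expected range of 15 nM to 300 nM.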

Compound 4, half-maximal inhibitory concentration: 201 nM
Compound 4: middle estimate off by 3.4-fold (0.53 log units), on the low side; the measured number falls inside the stated range.
By their numbers in this assay, from the lowest: compound 2; then compounds 1 and 4 (each within the scatter of the next). At a limit, above all of these: compound 3.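

With a phenyl ring on both sides of the change, benzoyl in place of benzyl on this nitrogen gives an at least 49-fold lower number from compound 3 to compound 4 (1.69 log units; beyond the scatter). The value of compound 3 is a limit, not a number: the limit of > 10000 nM in this assay, at which 1 of the 4 values shown sits.

The ring on the carbonyl also counts, since phenyl in place of pyridin-4-yl gives a 19-fold higher number from compound 2 to compound 4 (1.27 log units; beyond the scatter), whereas hydrogen in place of nitro gives a 1.7-fold higher number from compound 1 to compound 4 (0.24 log units; within the scatter).

Still open, on these data alone, is whether an amine or a carboxylic acid on that phenyl ring would give a number nearer that of compound 2. Also open, as far as these compounds go, is how a urea on this nitrogen would compare with the amides.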